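Series notes: from compound 2 to compound 3

The compounds below may be only part of what the source reports. "The series", "measured", "known", "first", "only" and "open" are said of these compounds alone.

Within the data shown here, compound 2 `C#Cc1nccc(C#Cc2ccc3ncn(-c4ccnc(N)n4)c3c2)n1` gives 39800 nM in an assay on Sf9 cells for inhibition of mitogen-activated protein kinase kinase kinase 14 variant S549D (Homo sapiens), with a stated time of 30 min, in the presence of a further agent that is not named here (on this read-out lower numbers stand for stronger inhibition and higher numbers for weaker inhibition), and stands at the top of the two numbers measured so far, though only within the scatter of compound 1 `C#Cc1cc(C#Cc2ccc3ncn(-c4ccnc(N)n4)c3c2)ccn1`, which in this assay gives 31600 nM. The step of a 1.3-fold higher number from compound 1 to compound 2 (0.10 log units; within the scatter) is within the scatter, so the two compounds cannot be told apart on this read-out.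

Compound 3 `Cc1ccnc(C#Cc2ccc3ncn(-c4ccnc(N)n4)c3c2)n1` differs from compound 2 as follows: a group of 7 heavy atoms (5 carbon, 2 nitrogen; one six-membered aromatic ring with 2 hetero atoms) in place of a group of 8 heavy atoms (6 carbon, 2 nitrogen; one six-membered aromatic ring with 2 hetero atoms), on a triple-bonded carbon. Among the measured compounds shown here, the only measured step, a 1.3-fold higher number from compound 1 to compound 2 (0.10 log units; within the scatter), swaps one ring for another on a triple-bonded carbon and keeps the triple bond; no measured pair removes that triple bond, so there is no direct precedent for the present change. With nothing pointing either way, the step is expected to be a 1.0-fold higher number from compound 2 to compound 3 (0.00 log units; within the scatter), none beyond the scatter. Compound 3 is therefore estimated at 40000 nM, with a range from 15000 nM to 110000 nM; at such weak levels a reading given only as a limit is possible.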

Compound 3, half-maximal inhibitory concentration: 1580 nM
Estimate against measurement, compound 3: 25-fold (1.40 log units) above, outside the stated range (below it).
By their numbers in this assay, from the lowest: compound 3; then compounds 1 and 2 (each within the scatter of the next).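

On the triple-bonded carbon, this position proves sensitive to the attached group in this assay: the 4-methylpyrimidin-2-yl group brings a 25-fold lower number from compound 2 to compound 3 (1.40 log units; beyond the scatter) and a 20-fold lower number from compound 1 to compound 3 (1.30 log units; beyond the scatter), whereas the earlier ring swap gave only a 1.3-fold higher number from compound 1 to compound 2 (0.10 log units; within the scatter), within the scatter. The outgoing groups in both new steps carry a triple bond outside aromatic rings and the 4-methylpyrimidin-2-yl group carries none, so the read-out at this place responds to more than the swap between the two earlier rings. No measurement at hand accounts for the stronger inhibition.

The steps change the ring and its substituent together, so the contributions of the triple bond, the methyl and the ring attachment remain unseparated. Also open, going by these compounds, is how an unsubstituted pyrimidin-2-yl, or a 4-methoxy or 4-amino group on that ring, would read here.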